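The source may hold more compounds than are shown below. What is called first, only, known or untested is meant among the compounds shown, and "the series" means these compounds.

Measured so far:
compound 1 `C=C1C2=C(C(=O)N1OC)[C@H](OC(=O)CSc1nc3ccccc3o1)[C@@](C)(O)[C@H](CCCCC)O2`, in a functional assay on PC-3 cells (Homo sapiens) for cytotoxicity, read by MTT assay, with a stated time of 72 h (on this read-out higher numbers stand for weaker inhibition and lower numbers for stronger inhibition), compound 1 gives 5800 nM
compound 2 `C=C1C2=C(C(=O)N1OC)[C@H](OC(=O)CSc1nc3ccccc3s1)[C@@](C)(O)[C@H](CCCCC)O2`, compound 2 gives 5000 nM
compound 3 `C=C1C2=C(C(=O)N1OC)[C@H](O)[C@@](C)(O)[C@H](CCCCC)O2`, compound 3 gives 32000 nM

Compound 1 stands second highest of these three numbers. Its nearest neighbour is compound 2, reached by a 1.2-fold lower number from compound 1 to compound 2 (0.06 log units; within the scatter), a swap of one ring-bearing group for another on the sulfur. Compound 3, whose structure differs more widely, gives the highest number of the set.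

Compound 4 `C=C1C2=C(C(=O)N1OC)[C@H](OC(=O)CCCCCl)[C@@](C)(O)[C@H](CCCCC)O2` is not yet measured. It differs from compound 1 as 3-chloropropyl in place of (1,3-benzoxazol-2-yl)sulfanyl on a saturated chain carbon bound to a carbonyl carbon. Among the measured compounds shown here, no measured pair tests this kind of change: the one measured step kept the sulfur and the attached ring system and stayed within the scatter, so it offers little guidance. The expected step is therefore a 1.4-fold higher number from compound 1 to compound 4 (0.14 log units; within the scatter), a modest rise in the number or none beyond the scatter. Compound 4 is estimated at 8000 nM, within 3500 nM to 18000 nM.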

Compound 4, half-maximal inhibitory concentration: 9200 nM
Compound 4: the middle estimate sits 1.2-fold (0.06 log units) below what was measured; low and high end bracket the measured number.
By their numbers in this assay, from the lowest: compounds 2, 1 and 4 (each within the scatter of the next); then compound 3.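

In this assay swapping the ring-bearing group for 3-chloropropyl, which has no ring, leaves the number within the scatter (a 1.6-fold higher number from compound 1 to compound 4 (0.20 log units; within the scatter)) and (a 1.8-fold higher number from compound 2 to compound 4 (0.26 log units; within the scatter)) so neither ring system is needed to hold this level. Even without a ring, (4-chlorobutyl)carbonyl in place of hydrogen on the oxygen gives a step beyond the scatter (a 3.5-fold lower number from compound 3 to compound 4 (0.54 log units; beyond the scatter)). Nothing available explains these results. Still open, on these data alone, is whether the chlorine matters, and whether an amine, a carboxylic acid or a longer chain would hold this level.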